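The source may report more compounds than this note shows. Statements on the series, on what has been measured and on what is new or still open speak of the compounds shown alone.

Working notes on the series. In a functional assay on HeLa cells (Homo sapiens) for cytotoxicity (a higher number here means a weaker inhibitor, a lower number a stronger inhibitor), compound 1 (`C=CCOc1ccc2c(c1)C(=O)C=CC2=O`) gives 27200 nM as its reading. Compound 2 (`CC(=O)Oc1ccc2c(c1)C(=O)C=CC2=O`) gives 27700 nM as its reading, which places it level with compound 1 on the two numbers available, with no order between them. Among the compounds with values here, the one measured step is a 1.0-fold higher number from compound 1 to compound 2 (0.01 log units; within the scatter) and it concerns acetyl in place of allyl on an oxygen on an aromatic ring.

Compound 3 (`O=C(Oc1ccc2c(c1)C(=O)C=CC2=O)c1ccccc1`) has not yet been measured. It differs from compound 2 by phenyl in place of methyl on a carbonyl carbon. Within the data shown here, no measured compound carries this phenyl, so the data offer no direct precedent for the change and no direction for it. Among the measured compounds shown here, the expectation therefore rests on a 1.0-fold higher number from compound 1 to compound 2 (0.01 log units; within the scatter) as its sole guide, and that is thin evidence for a different kind of change. In this assay no change beyond the scatter is expected, and the estimated step is a 1.1-fold lower number from compound 2 to compound 3 (0.04 log units; within the scatter) with no firm direction. For compound 3 the estimated value is 25000 nM with an expected range from 11000 nM to 50000 nM for the coming measurement.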

Compound 3, half-maximal inhibitory concentration: 19200 nM
Compound 3: the middle estimate sits 1.3-fold (0.11 log units) above what was measured; the measured number falls inside the stated range.
By their numbers in this assay, from the lowest: compounds 3, 1 and 2 (each within the scatter of the next).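

In this assay, the step is a 1.4-fold lower number from compound 2 to compound 3 (0.16 log units; within the scatter), so placing one six-membered aromatic ring of carbon only on the carbonyl carbon, where methyl stood, gives a reading that stays within the scatter. The earlier pair showed only that acetyl and allyl on the oxygen could be exchanged without a change beyond the scatter; this step extends that observation to a phenyl on the carbonyl carbon, so that all three substituents shown on this oxygen read alike in this assay. No information is available on what lies behind this flat reading.

Going by these compounds, whether an amine or a carboxylic acid on the phenyl, or a longer chain in place of it, would move the reading beyond the scatter remains open. All three compounds share the same core and differ only in what sits on this one oxygen, so they leave open how far changes elsewhere on the core, or a free hydroxyl at this oxygen, would shift the number.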